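Fluoro in Place of Hydrogen on an Aromatic Carbon

This account rests on a few compounds, and the source may have more. Where it says the series, first, only, none or still open, it means among the compounds named here.

In a physicochemical assay for solubility (on this read-out higher numbers stand for higher solubility and lower numbers for lower solubility), compound 1 `COc1cc(OC)c(/C=C/S(=O)(=O)Nc2ccc(OC)c(NC(C)C(=O)O)c2)c(OC)c1` gives 10000 ug/mL, and compound 2 `COc1cc(OC)c(/C=C/S(=O)(=O)Nc2ccc(OC)c(NC(C(=O)O)c3ccccc3)c2)c(OC)c1` gives 10000 ug/mL. Compound 2 thus stands level with compound 1 at the digits available, and it is the closest measured neighbour of the compound still awaiting its result. Compound 3 `COc1cc(OC)c(/C=C/S(=O)(=O)Nc2ccc(OC)c(NC(C(=O)O)c3ccc(F)cc3)c2)c(OC)c1` differs from compound 2 in one place: fluoro in place of hydrogen on an aromatic carbon, para to a large group, which turns phenyl to 4-fluorophenyl (fluoro in place of hydrogen on an aromatic carbon). Within the data shown here, only one measured step bears on this change, and only indirectly. With phenyl in place of methyl on a saturated chain carbon, the series showed no change at the digits printed from compound 1 to compound 2 (within the scatter). Among the measured compounds shown here, that swap was a larger structural change than the one now at hand, and no measured pair tests a fluoro group directly. On this limited evidence, no shift beyond the scatter is expected in this assay. The expected step is no change at the digits printed from compound 2 to compound 3 (within the scatter). For compound 3 the estimated value is 10000 ug/mL, with an expected range of 5000 ug/mL to 12000 ug/mL.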

Compound 3, solubility: 10000 ug/mL
Compound 3: the middle estimate sits on the measured number at the digits printed; the measured number falls inside the stated range.
By their numbers in this assay, from the lowest: compounds 1, 2 and 3 (each within the scatter of the next).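

In this assay, among these compounds, fluoro on an aromatic carbon para to a large group gives no change at the digits printed from compound 2 to compound 3 (within the scatter), which is the first direct reading of this change at this position. The wider step, with 4-fluorophenyl in place of methyl on the saturated chain carbon, reads no change at the digits printed from compound 1 to compound 3 (within the scatter), so the read-out now separates neither of the two ring-bearing compounds from the methyl compound, and the series holds one level across all three. Nothing measured here offers an explanation for this flat result.

What the compounds shown leave open is whether a different group at this same ring position, such as chloro, trifluoromethyl or dimethylamino, would also stay level in this assay, and whether fluoro on another carbon of the ring would do the same. They also leave open how the read-out would respond to a change elsewhere in the molecule, for example a methyl ester in place of the carboxy group on the saturated chain carbon, since every compound here carries that same carboxy group.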